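The source may hold more compounds than are shown below. What is called first, only, known or untested is meant among the compounds shown, and "the series" means these compounds.

In a functional assay on HeLa cells (Homo sapiens) for inhibition, read by sulforhodamine B assay (on this read-out lower numbers stand for stronger inhibition and higher numbers for weaker inhibition), compound 1 `O=C1C=C(NC2CCCCC2)C(=O)c2c1nc1n2[C@H]2OC[C@@H](O)[C@H]2OC1` reads > 16000 nM, which is a limit of the assay and not a number. For the measured compounds named here, compound 2 `O=C1C=C(Nc2ccccc2)C(=O)c2c1nc1n2[C@H]2OC[C@@H](O)[C@H]2OC1` gives 5620 nM, the only true number so far. Compound 3 `O=C1C=C(N2CCCC2)C(=O)c2c1nc1n2[C@H]2OC[C@@H](O)[C@H]2OC1` has pyrrolidin-1-yl in place of anilino on a double-bonded ring carbon. Going by the values given here, the one measured step that bears on this is an at least 2.8-fold lower number from compound 1 to compound 2 (0.45 log units; beyond the scatter). That step put an aromatic ring in place of a non-aromatic one, and here the swap runs the other way, so weaker inhibition is expected. The expected change is a 2.1-fold higher number from compound 2 to compound 3 (0.33 log units; beyond the scatter). For compound 3 the estimated value is 12000 nM, with an expected range of 4000 nM to 35000 nM.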

Compound 3, half-maximal inhibitory concentration: > 16000 nM
Compound 3 was reported as a limit (the forecaster's own chance of this, stated with the estimate: 40%); at least 1.3-fold (0.12 log units) between middle value and limit.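

At this double-bonded ring carbon, pyrrolidin-1-yl in place of anilino gives an at least 2.8-fold higher number from compound 2 to compound 3 (0.45 log units; beyond the scatter). Of the three groups shown, only anilino, the one with an aromatic ring, gives a true number, while compound 1 and compound 3, with non-aromatic rings, both end at a limit. The step between compound 1 and compound 3 cannot be read, as both stop at the same point: the limit of > 16000 nM in this assay, at which 2 of the 3 values shown sit.

Going by these compounds, compound 1 keeps the hydrogen-bond donor without the aromatic ring, but the reverse case stays open. A methylanilino group, which has the aromatic ring and no such donor, would test it.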